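Aziridinylquinone side chain: ester-like acetyl swapped for hydroxymethoxyethyl

A few compounds are considered here, and "the series" means these few. Any claim that something is new, unique, unknown or untested is made for them only; others in the source may bear on it.

Three aziridinyl quinones have been measured in a functional assay on L1210 cells (Mus musculus), with a stated time of 1 days; on this read-out lower numbers stand for lower potency and higher numbers for higher potency (the scale is a negative logarithm). Compound 1 `COCCC1=C(N2CC2)C(=O)C(CCOC)=C(N2CC2)C1=O` gives 5.18, compound 3 `CC(C)C1=C(N2CC2)C(=O)C(C(C)C)=C(N2CC2)C1=O` gives 4.36, and compound 2 `CC(=O)C1=C(N2CC2)C(=O)C(C)=C(N2CC2)C1=O` gives 3.94. Compound 2 therefore stands lowest of the three, with compound 3 nearest and compound 1 furthest, both of them beyond the usual scatter above it. Among the compounds with values here, no single-point step between measured compounds exists, so the size of the change from compound 2 to compound 4 `COC(CO)C1=C(N2CC2)C(=O)C(C)=C(N2CC2)C1=O` cannot be read off directly.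

The change is 2-hydroxy-1-methoxyethyl in place of acetyl on a double-bonded ring carbon. The side chain that enters carries an ether oxygen like the methoxyethyl chains of compound 1, and compound 1 is the most potent of the measured set. Compound 4 is therefore expected to gain over compound 2 by a step of a number 0.76 log units higher from compound 2 to compound 4 (beyond the scatter), though the size of that rise is uncertain because compound 1 gives 5.18 with two such chains rather than one. Compound 4 is estimated at 4.7, within 4.1 to 5.3.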

Compound 4, logarithm of the reciprocal of the active concentration, log(1/C): 6.05
Beside the measured number, compound 4's estimate is 1.35 log units below it; the whole stated range lies below it.
By their numbers in this assay, from the lowest: compound 2; then compound 3; then compound 1; then compound 4.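

In this assay the series now has its first step at a single place, a number 2.11 log units higher from compound 2 to compound 4 (beyond the scatter), with the rest of the structure unchanged. Within the data shown here, this shows that the double-bonded ring carbon next to the ring atom that bears an aziridin-1-yl group is strongly sensitive to its substituent, which the earlier compounds, differing from one another in more than one place, could not show. Nothing shown here accounts for the size of this rise.

Among these compounds, the single step cannot separate the loss of acetyl from the entry of the hydroxyl or the methoxy part of the new chain. On these data alone, what a 2-hydroxyethyl chain or an amine would give on this carbon remains open, as does whether the rise would hold with something other than methyl on the far ring carbon.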